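Benzyl to hydrogen on an oxygen: what to expect

The source may hold more compounds than are shown below. What is called first, only, known or untested is meant among the compounds shown, and "the series" means these compounds.

Measured in a functional assay on HOS cells (Homo sapiens) for antiproliferative activity, read by sulforhodamine B assay; a lower number here means a stronger inhibitor of growth, a higher number a weaker inhibitor of growth:
- Compound 1 `CCC[C@@H]1O[C@H](COCc2ccccc2)[C@@H](OCc2ccccc2)[C@H](OCc2ccccc2)[C@H]1O`: 38600 nM
- Compound 2 `O[C@@H]1[C@@H](OCc2ccccc2)[C@H](OCc2ccccc2)[C@@H](COCc2ccccc2)O[C@H]1c1ccccc1`: > 50000 nM, which is a limit of the assay
- Compound 3 `O[C@@H]1[C@@H](OCc2ccccc2)[C@H](OCc2ccccc2)[C@@H](COCc2ccccc2)O[C@H]1Cc1ccccc1`: 29200 nM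

Compound 3 cannot be told apart from its nearest neighbour, as the step of a 1.3-fold lower number from compound 1 to compound 3 (0.12 log units; within the scatter) shows. The other step reaching it is an at least 1.7-fold lower number from compound 2 to compound 3 (0.23 log units; that floor lies within the scatter). In compound 4 `O[C@@H]1[C@@H](O)[C@H](Cc2ccccc2)O[C@H](COCc2ccccc2)[C@H]1OCc1ccccc1`, hydrogen comes in place of benzyl on an oxygen on a saturated carbon (hydrogen in place of benzyl on an oxygen on a saturated carbon). Neither step changes that place, so they offer only a loose guide: the group swaps seen so far moved this assay little. All these numbers lie close to the limit (the limit of > 50000 nM in this assay, at which 1 of the 3 values shown sits). A small move toward a higher number is therefore expected, possibly none beyond the scatter, and the expected step is a 1.4-fold higher number from compound 3 to compound 4 (0.16 log units; within the scatter). For compound 4 the estimated value is 42000 nM, with an expected range of 18000 nM to 90000 nM.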

Compound 4, concentration for 50% growth inhibition: 33500 nM
For compound 4 the middle estimate is 1.3-fold (0.10 log units) above the measured one; measured number inside the range.
By their numbers in this assay, from the lowest: compounds 3, 4 and 1 (each within the scatter of the next). At a limit, above all of these: compound 2.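

Putting hydrogen in place of benzyl on this oxygen gives a 1.1-fold higher number from compound 3 to compound 4 (0.06 log units; within the scatter) in this assay. The benzyl group on this oxygen, with its whole aromatic ring, can therefore be lost while compound 3 and compound 4 remain indistinguishable, which the earlier swaps on ring and chain carbons could not show. Still, this reading has little room to show much: the limit of > 50000 nM in this assay, at which 1 of the 4 values shown sits.

Going by these compounds, whether an amine or a methyl ether at this place would read the same stays open. So does the effect of replacing the other benzyl groups with hydrogen.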